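Cycloheptyl to 4-methylcyclohexyl on the amide nitrogen

A few compounds are considered here, and "the series" means these few. Any claim that something is new, unique, unknown or untested is made for them only; others in the source may bear on it.

Notes on a small amide series sharing one core, read in an ADME assay on MRC5 cells (Homo sapiens) for inhibition, with a stated time of 72 h; a higher number here means that more compound is needed for the effect, a lower number that less compound is needed. For the measured compounds named here, compound 3 `COc1cccc(OC)c1C(=O)Nc1c[nH]nc1C(=O)NC1CCCCCC1` gives 42000 nM, the only true number so far. Compound 1 `COc1cccc(OC)c1C(=O)Nc1c[nH]nc1C(=O)NCC1CCCCC1` reads > 50000 nM, which is a limit of the assay. Compound 2 `COc1cccc(OC)c1C(=O)Nc1c[nH]nc1C(=O)NCCCOC(C)C` reads > 50000 nM, again a limit. The data therefore sit close to the limit of > 50000 nM in this assay, at which 2 of the 3 values shown sit, and compound 3 stands just inside that ceiling.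

The next compound, compound 4 `COc1cccc(OC)c1C(=O)Nc1c[nH]nc1C(=O)NC1CCC(C)CC1`, carries 4-methylcyclohexyl in place of cycloheptyl on an amide-type nitrogen.

Going by the values given here, two measured steps bear on this change, since both alter the same amide-type nitrogen substituent: an at least 1.1-fold lower number from compound 1 to compound 3 (0.07 log units; that floor lies within the scatter) and an at least 1.1-fold lower number from compound 2 to compound 3 (0.07 log units; that floor lies within the scatter). Both are only floors and neither shows a change beyond the scatter. The remaining step, a step that the two limits leave unreadable from compound 1 to compound 2, gives no size. Nothing measured therefore supports a real shift in this assay, in either direction, and none beyond the scatter is expected. The expected step is a 1.1-fold lower number from compound 3 to compound 4 (0.02 log units; within the scatter). A result reported only as a limit would also fit this expectation. For compound 4 the estimated value is 40000 nM, with an expected range of 18000 nM to 60000 nM.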

Compound 4, half-maximal effective concentration: 45000 nM
For compound 4 the middle estimate is 1.1-fold (0.05 log units) below the measured one, and the stated range covers the measured number.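

In this assay, rearranging the carbons of the substituent on the amide-type nitrogen from one seven-membered ring to one six-membered ring bearing a methyl group brings no change beyond the scatter (a 1.1-fold higher number from compound 3 to compound 4 (0.03 log units; within the scatter)), so this exchange of cycloheptyl for 4-methylcyclohexyl, with the heavy-atom count unchanged, leaves the read-out where it was. Against the two compounds that read only as limits, the new floors (an at least 1.1-fold lower number from compound 2 to compound 4 (0.04 log units; that floor lies within the scatter) and an at least 1.1-fold lower number from compound 1 to compound 4 (0.04 log units; that floor lies within the scatter)) also stay within the scatter and add no readable difference to those seen before. This position now has a second true number, and the two ring compounds with true numbers lie close to the ceiling of the assay: the limit of > 50000 nM in this assay, at which 2 of the 4 values shown sit.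

On these data alone, whether a carboxylic acid, a piperidine amine or a phenyl ring on this amide-type nitrogen would bring the number well clear of that ceiling stays open. All the changes shown are confined to this one substituent, so the effect of altering the shared core also stays open.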